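The compounds below may be only part of what the source reports. "The series", "measured", "known", "first", "only" and "open" are said of these compounds alone.

Measured in a functional assay on NCI-H1299 cells (Homo sapiens) for inhibition, read by CCK-8 assay, with a stated time of 72 h, tested at 10 uM; a higher number here means more inhibition of growth at the concentration tested, a lower number less inhibition of growth:
Compound 1 `CN(C)C(=O)c1cc2cnc(Nc3ccc(NC(=O)C4(C(=O)Nc5ccc(F)cc5)CC4)cc3)nc2n1C1CCCC1`: 90.8%
Compound 2 `CN(C)C(=O)c1cc2cnc(Nc3ccc(NC(=O)C4(C(=O)Nc5cccc(Cl)c5)CC4)cc3)nc2n1C1CCCC1`: 84.1%
Compound 3 `CN(C)C(=O)c1cc2cnc(Nc3ccc(NC(=O)C4(C(=O)Nc5ccc(F)cc5)CC4)cc3F)nc2n1C1CCCC1`: 82.6%

At 84.1%, compound 2 lies within the scatter of both other compounds. Compound 4 `CN(C)C(=O)c1cc2cnc(Nc3ccc(NC(=O)C4(C(=O)Nc5ccccc5)CC4)cc3)nc2n1C1CCCC1` is still unmeasured and differs from it as follows: hydrogen in place of chloro on an aromatic carbon. This puts hydrogen in place of chloro on an aromatic carbon. Going by the values given here, two measured steps bear on this. The change to 3-chlorophenyl in place of 4-fluorophenyl gave a number 6.7 percentage points lower from compound 1 to compound 2 (within the scatter), and fluoro in place of hydrogen on an aromatic carbon gave a number 8.2 percentage points lower from compound 1 to compound 3 (within the scatter). Among the compounds with values here, neither step leaves the scatter, though no measured compound carries the plain phenyl group. No step beyond the scatter is therefore expected in this assay, and the estimated change is a number 0.9 percentage points higher from compound 2 to compound 4 (within the scatter). Compound 4 is expected at 85%, within an estimated range of 74% to 95%.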

Compound 4, percent growth inhibition at one concentration: 90.5%
Compound 4: middle estimate off by 5.5 percentage points, on the low side; low and high end bracket the measured number.
By their numbers in this assay, from the lowest: compounds 3, 2, 4 and 1 (each within the scatter of the next).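

In this assay, hydrogen in place of chloro on the 3-chlorophenyl group gave a number 6.4 percentage points higher from compound 2 to compound 4 (within the scatter) and hydrogen in place of fluoro on the 4-fluorophenyl group gave a number 0.3 percentage points lower from compound 1 to compound 4 (within the scatter) for the plain phenyl compound. With phenyl now measured, neither halogen on this ring shifts the number beyond the scatter when compared directly with hydrogen. Nothing available gives a cause for these steps. Left open is whether a methoxy group, an amine or a carboxylic acid on this ring would also stay within the scatter.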